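A few compounds are considered here, and "the series" means these few. Any claim that something is new, unique, unknown or untested is made for them only; others in the source may bear on it.

Compounds measured in a functional assay on the whole organism for inhibition, with Rattus norvegicus as the target, read by cytopathic effect and paw edema, at a dose of 100 mg/kg by the oral route; on this read-out higher numbers stand for more inhibition at the one dose given (going by the name of the read-out) and lower numbers for less inhibition:
compound 1, `CCOC(=O)c1c(O)c2cccnc2n(-c2ccccc2)c1=O`: 15.5%
compound 2, `Cc1ccc(NC(=O)c2c(O)c3cccnc3n(-c3ccccc3)c2=O)cc1`: 2.2%
compound 3, `Nc1ccc(NC(=O)c2c(O)c3cccnc3n(-c3ccccc3)c2=O)cc1`: 0%

Compound 3 stands lowest of the three numbers. Its nearest neighbour is compound 2, a number 2.2 percentage points lower from compound 2 to compound 3 (within the scatter); its furthest is compound 1, a number 15.5 percentage points lower from compound 1 to compound 3 (beyond the scatter). Compound 4, `O=C(Nc1cccnc1)c1c(O)c2cccnc2n(-c2ccccc2)c1=O`, differs from compound 3 in one place: pyridin-3-yl in place of 4-aminophenyl on an amide-type nitrogen. Among the compounds with values here, the steps that bear on it are the two from the ester to an aryl amide, a number 13.3 percentage points lower from compound 1 to compound 2 (beyond the scatter) and a number 15.5 percentage points lower from compound 1 to compound 3 (beyond the scatter), which left both amides low, and the change of the aryl substituent, a number 2.2 percentage points lower from compound 2 to compound 3 (within the scatter), which lay within the scatter. Compound 4 keeps the aryl amide, so no step beyond the scatter in this assay is expected, a number 3 percentage points higher from compound 3 to compound 4 (within the scatter). Compound 4 is estimated at 3%, within 0% to 12%.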

Compound 4, a percentage reported as inhibition, in the whole organism at one dose (the size of the read-out at that dose, not a potency): 30.8%
For compound 4 the middle estimate is 27.8 percentage points below the measured one, outside the stated range (above it).
By their numbers in this assay, from the lowest: compounds 3 and 2 (each within the scatter of the next); then compound 1; then compound 4.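

In this assay the group on the amide-type nitrogen proves able to move the number: pyridin-3-yl in place of 4-aminophenyl gives a number 30.8 percentage points higher from compound 3 to compound 4 (beyond the scatter) and pyridin-3-yl in place of 4-methylphenyl gives a number 28.6 percentage points higher from compound 2 to compound 4 (beyond the scatter), although the earlier change on the aromatic carbon stayed within the scatter. Replacing ethoxy no longer lowers the number, since (pyridin-3-yl)amino gives a number 15.3 percentage points higher from compound 1 to compound 4 (beyond the scatter). No evidence given here accounts for this rise. As far as these compounds go, whether pyridin-2-yl or pyridin-4-yl would behave like pyridin-3-yl remains open, as does the outcome with a simple phenyl group on that nitrogen.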